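The compounds below may be only part of what the source reports. "The series", "measured", "known", "first", "only" and "open" are said of these compounds alone.

Working notes on the series. Compound 1 `C=CCn1c(=O)/c(=C\c2ccccc2OC)[nH]c(=O)/c1=C\c1ccccc1OC` is the reference member of the shared core; in a functional assay on HL-60 cells (Homo sapiens) for cytotoxicity, read by CCK-8 assay, with a stated time of 72 h (a higher number here means a weaker inhibitor, a lower number a stronger inhibitor), compound 1 gives 15700 nM. Compound 2 `C=CCn1c(=O)/c(=C\c2ccc(C)cc2)[nH]c(=O)/c1=C\c1ccccc1OC` gives "not active" (no number reported) in this assay, so it supplies no number for comparison. Among the compounds with values here, compound 3 `C=CCn1c(=O)/c(=C\c2ccccc2C(F)(F)F)[nH]c(=O)/c1=C\c1ccccc1OC` gives 4600 nM in this assay, the lowest of the two numbers reported so far; its only neighbour with a number is compound 1, separated by the single recorded step a 3.4-fold lower number from compound 1 to compound 3 (0.53 log units; beyond the scatter), which is modest but beyond the scatter.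

Compound 4 `C=CCn1c(=O)/c(=C\c2cccc(Cl)c2Cl)[nH]c(=O)/c1=C\c1ccccc1OC` is the next entry. Its change from compound 3: 2,3-dichlorophenyl in place of 2-(trifluoromethyl)phenyl on a double-bonded chain carbon bound to an aromatic carbon. Within the data shown here, no measured step swaps one substituted phenyl for another of this kind, so the step of a 3.4-fold lower number from compound 1 to compound 3 (0.53 log units; beyond the scatter) is the only evidence that bears on it, and it shows that trifluoromethyl in place of methoxy lowered the number, while compound 2 with methyl gave "not active" (no number reported). With 2,3-dichlorophenyl entering where 2-(trifluoromethyl)phenyl leaves, compound 4 is expected to stay near compound 3, and the step of a 1.3-fold lower number from compound 3 to compound 4 (0.12 log units; within the scatter) is expected to remain within or close to the scatter. The estimate for compound 4 in this assay is 3500 nM, with a range from 1200 nM to 11000 nM.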

Compound 4, half-maximal inhibitory concentration: 2000 nM
For compound 4 the middle estimate is 1.8-fold (0.24 log units) above the measured one; measured number inside the range.
By their numbers in this assay, from the lowest: compound 4; then compound 3; then compound 1.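

In this assay, 2,3-dichlorophenyl gives a 2.3-fold lower number from compound 3 to compound 4 (0.36 log units; beyond the scatter), so this place on the series still responds when one substituted phenyl replaces another, and 2-(trifluoromethyl)phenyl does not mark the low end of the numbers. Measured against the reference, the same place gives a 7.9-fold lower number from compound 1 to compound 4 (0.89 log units; beyond the scatter), a larger step than a 3.4-fold lower number from compound 1 to compound 3 (0.53 log units; beyond the scatter), so compound 4 now has the lowest number among compounds 1, 3 and 4, although compound 2 stands apart from this trend of replacing 2-methoxyphenyl with a lower number, giving "not active" (no number reported). No available measurement bears on what underlies this order among the compounds.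

The compounds shown leave open whether a phenyl carrying a single chlorine would match 2,3-dichlorophenyl, and whether an amine or a carboxylic acid on this phenyl would be tolerated at all. They also leave open how far these steps carry over once the 2-methoxyphenyl group, common to all four compounds, is replaced, for example by a second 2,3-dichlorophenyl.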